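The compounds below may be only part of what the source reports. "The series", "measured", "known", "first", "only" and "open" are said of these compounds alone.

Measured so far:
Compound 1, `Cc1ccc(-c2cc(N)n3nc(-c4ccc(Cl)cc4)cc3n2)cc1`: 69.5%
Compound 2, `Cc1ccc(-c2cc(N)n3nc(-c4ccccc4)cc3n2)cc1`: 31.7%
Compound 3, `Nc1cc(-c2ccc(Cl)cc2)nc2cc(-c3ccc(Br)cc3)nn12`: 56.1%

In a functional assay on the whole organism (strain Wistar) for inhibition, with Rattus norvegicus as the target, read by paw edema, with stated times of 30 min and 3 h, at a dose of 50 mg/kg by the oral route (a lower number here means less inhibition, a higher number more inhibition at the dose given (going by the name of the read-out)), compound 3 stands second of the three, with compound 1 above it and compound 2 below it, both gaps beyond the scatter. Compound 4, `Cc1ccc(-c2cc(N)n3nc(-c4ccc(Br)cc4)cc3n2)cc1`, differs from compound 3 by methyl in place of chloro on an aromatic carbon, the 4-chlorophenyl becoming 4-methylphenyl. Going by the values given here, no measured step covers this change. Among the compounds with values here, the only measured step, a number 37.8 percentage points lower from compound 1 to compound 2 (beyond the scatter), concerns a different ring, so it offers no direct guide. Compound 4 shares the 4-methylphenyl of compound 1, whose value in this assay is the highest shown, which suggests a moderate rise; the estimate for compound 4 is 63%, within 45% to 78%, an expected step of a number 6.9 percentage points higher from compound 3 to compound 4 (within the scatter).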

Compound 4, a percentage reported as inhibition, in the whole organism at one dose (the size of the read-out at that dose, not a potency): 73.2%
Compound 4: middle estimate off by 10.2 percentage points, on the low side; the range from low to high includes it.
By their numbers in this assay, from the lowest: compound 2; then compound 3; then compounds 1 and 4 (each within the scatter of the next).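

In this assay the change from 4-chlorophenyl to 4-methylphenyl gives a number 17.1 percentage points higher from compound 3 to compound 4 (beyond the scatter) and so shows that this ring also affects the result, not only the ring carrying the halogen. On that other ring, bromo in place of hydrogen gives a number 41.5 percentage points higher from compound 2 to compound 4 (beyond the scatter) and bromo in place of chloro gives a number 3.7 percentage points higher from compound 1 to compound 4 (within the scatter), which leaves the two halogens indistinguishable here. Going by these compounds, whether an amine or a longer chain on the 4-methylphenyl ring's position would keep this level remains open. Nothing available explains these steps.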